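A few compounds are considered here, and "the series" means these few. Any claim that something is new, unique, unknown or untested is made for them only; others in the source may bear on it.

Of the compounds shown here, three have been measured so far in a functional assay on Raji cells (Homo sapiens) for cytotoxicity, with a stated time of 72 h (on this read-out higher numbers stand for an effect only at larger amounts of compound and lower numbers for an effect already at smaller amounts), and none of them gives an exact number. Compound 1 (`COc1ccc(/C=C/[C@@](C)(/C=C/c2ccc(O)c(/C=C/C#N)c2)CCC=C(C)C)cc1`) gives > 26000 nM as a limit of the assay and not a number. Compound 2 (`CCOC(=O)/C=C/c1cc(/C=C/[C@](C)(/C=C/c2ccc(OC)cc2)CCC=C(C)C)ccc1O`) gives > 26000 nM as a limit too. Compound 3 (`CCOC(=O)/C(C)=C/c1cc(/C=C/[C@](C)(/C=C/c2ccc(OC)cc2)CCC=C(C)C)ccc1O`) also stands at > 26000 nM as a limit, so it cannot be ranked against the others. The whole picture so far is the limit of > 26000 nM in this assay, at which 3 of the 3 values shown sit, and nothing finer.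

Compound 4 (`COc1ccc(/C=C/[C@@](C)(/C=C/c2ccc(O)c(/C=C/C(=O)OC(C)(C)C)c2)CCC=C(C)C)cc1`) differs from compound 3 in one group on an aromatic carbon ortho to a hydroxy group. That difference is 2-(tert-butoxycarbonyl)ethenyl in place of 2-(ethoxycarbonyl)prop-1-en-1-yl on an aromatic carbon in full, with 2-(tert-butoxycarbonyl)ethenyl in place of 2-(ethoxycarbonyl)prop-1-en-1-yl.

Three measured steps changed the same chain: a step that the two limits leave unreadable from compound 1 to compound 2 and a step that the two limits leave unreadable from compound 1 to compound 3 and a step that the two limits leave unreadable from compound 2 to compound 3 in turn. None of them has a readable size, and each left the compounds at the limit. With compound 3 held at > 26000 nM as a limit, no shift beyond the scatter is expected in this assay in either direction. The expected step is a step that the limit leaves unreadable from compound 3 to compound 4 as an estimate only. For compound 4 the estimated value is 30000 nM with an expected range from 12000 nM to 60000 nM and a report of only a limit is the likeliest outcome.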

Compound 4, half-maximal effective concentration: > 26000 nM
Compound 4: no number, only a limit; the forecaster's own chance of this, stated with the estimate: 85%; the middle value is on the limit's open side.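

Among the compounds shown here, compound 4 also stands only at a limit in this assay, so no step linking it to compound 1, compound 2 or compound 3 can be read. The picture remains: the limit of > 26000 nM in this assay, at which 4 of the 4 values shown sit. The compounds shown leave open where each true value lies and whether changing this group alters the read-out at all.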